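Swapping the ring substituent of a potent dihydropyridine

The compounds below may be only part of what the source reports. "The series", "measured", "known", "first", "only" and "open" are said of these compounds alone.

Compound 1, `C=Cc1ccccc1C1C(C(=O)OC)=C(C)N=C(C)/C1=C(\O)OC`, is the stronger of the two measured compounds. In a functional assay (muscle tissue) with Cavia porcellus as the target (on this read-out higher numbers stand for an effect only at larger amounts of compound and lower numbers for an effect already at smaller amounts), compound 1 gives 4.47 nM, the lowest of the two numbers recorded. Going by the values given here, its nearest neighbour, compound 2, `COC(=O)C1=C(C)N=C(C)/C(=C(\O)OC)C1c1ccc(Br)cc1`, gives 540 nM in this assay; the only change between them is a 4-bromophenyl in place of a 2-vinylphenyl on a saturated ring carbon, and it brings a 120-fold higher number from compound 1 to compound 2 (2.08 log units; beyond the scatter).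

Compound 3, `COC(=O)C1=C(C)N=C(C)/C(=C(\O)OC)C1c1ccccc1C(F)(F)F`, is not yet measured. It differs from compound 1 in one place: trifluoromethyl in place of vinyl on an aromatic carbon. Among the compounds with values here, only the step from compound 1 to compound 2 bears on this change, and only loosely, since there the group on the aromatic ring moved to another aromatic carbon at the same time as it changed. That step was large and went toward a higher number, so some loss from compound 1 cannot be ruled out here, but keeping the new group ortho to a large group, where the vinyl stood, argues for a smaller shift. Compound 3 is therefore expected to give 12 nM in this assay, between 3 nM and 60 nM, corresponding to an expected step of a 2.7-fold higher number from compound 1 to compound 3 (0.43 log units; beyond the scatter).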

Compound 3, half-maximal effective concentration: 1.51 nM
For compound 3 the middle estimate is 7.9-fold (0.90 log units) above the measured one; measured number below the stated range.
By their numbers in this assay, from the lowest: compound 3; then compound 1; then compound 2.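

Trifluoromethyl in place of vinyl on an aromatic carbon ortho to a large group brings a 3.0-fold lower number from compound 1 to compound 3 (0.47 log units; beyond the scatter) in this assay and so shows that a low number at this place does not depend on vinyl. The double bond outside aromatic rings that vinyl carries is not needed here, and the larger count of heavy atoms in trifluoromethyl comes with no rise in the number. The earlier step of a 120-fold higher number from compound 1 to compound 2 (2.08 log units; beyond the scatter) could not show this, since both the group and its place on the aromatic ring changed at once, whereas here the place stays the same and only the group changes.

The compounds shown leave open whether other groups at this same place, such as a bromine atom, an amine or a longer chain, would also keep the number low, and a bromine there would help separate the effect of the group from that of its place in compound 2. Nothing measured here speaks to why trifluoromethyl gives the lower number.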